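The compounds below may be only part of what the source reports. "The series", "measured", "known", "first", "only" and "open" are said of these compounds alone.

In a functional assay on PANC-1 cells (Homo sapiens) for cytotoxicity, read by WST assay, with a stated time of 24 h (on this read-out lower numbers stand for stronger inhibition and higher numbers for weaker inhibition), compound 1 (`Cc1ccc(CCCCCCCCC(=O)N2CCCCC2)cc1`) gives > 100000 nM, which is a limit of the assay and not a number. Compound 2 (`O=C(CCCCCCCCc1ccc(O)cc1)N1CCCCC1`) gives > 100000 nM, and this too is only a limit. Going by the values given here, the one measured step is a step that the two limits leave unreadable from compound 1 to compound 2, with hydroxy in place of methyl on an aromatic carbon. All the evidence so far is the limit of > 100000 nM in this assay, at which 2 of the 2 values shown sit. Compound 3 (`COc1ccc(CCCCCCCCC(=O)N2CCCCC2)cc1`) differs from compound 2 by methyl in place of hydrogen on an oxygen on an aromatic ring, so that 4-hydroxyphenyl becomes 4-methoxyphenyl. Because a step that the two limits leave unreadable from compound 1 to compound 2 offers no readable size to carry over, no step beyond the scatter is expected in this assay, in either direction, and another limit is the likeliest report. The expected step is a step that the limit leaves unreadable from compound 2 to compound 3. For compound 3 the estimated value is 120000 nM, with an expected range of 50000 nM to 300000 nM.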

Compound 3, half-maximal inhibitory concentration: 89300 nM
The estimate for compound 3 lay 1.3-fold (0.13 log units) above the measured number; the range from low to high includes it.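

In this assay, going by these compounds alone, compound 3 carries the only readable number among the three compounds, so the 4-methoxyphenyl group ties this position to a value and not only to a limit. Methyl in place of hydrogen on the oxygen gives an at least 1.1-fold lower number from compound 2 to compound 3 (0.04 log units; that floor lies within the scatter), and methoxy in place of methyl on the aromatic carbon gives an at least 1.1-fold lower number from compound 1 to compound 3 (0.04 log units; that floor lies within the scatter); both are floors within the scatter, so the true size of neither step can be told. The other two values remain limits of the assay and not numbers: the limit of > 100000 nM in this assay, at which 2 of the 3 values shown sit.

From the compounds shown here alone, whether an amine or a carboxylic acid at this position would give a number well clear of that limit stays open. So does the effect of a longer chain on the shared core.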